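This account rests on a few compounds, and the source may have more. Where it says the series, first, only, none or still open, it means among the compounds named here.

Values in a functional assay on HCT-116 cells (Homo sapiens) for inhibition, read by MTT assay, with a stated time of 72 h (a higher number here means a weaker inhibitor, a lower number a stronger inhibitor), for the three measured compounds are these:

- compound 1 `Nc1nc2cc(-c3nn(CCCC(=O)NO)c4ncnc(N)c34)ccc2o1` gives 19600 nM
- compound 2 `Nc1nc2cc(-c3nn(CCCCCCCCCC(=O)NO)c4ncnc(N)c34)ccc2o1` gives 23100 nM
- compound 3 `Nc1nc2cc(-c3nn(CCCCCC(=O)NO)c4ncnc(N)c34)ccc2o1` gives 21500 nM

Compound 3 at 21500 nM stands with the other two inside the scatter. The steps that reach it are a 1.1-fold higher number from compound 1 to compound 3 (0.04 log units; within the scatter) and a 1.1-fold lower number from compound 2 to compound 3 (0.03 log units; within the scatter) and neither separates it from the others.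

The change to compound 4 `Nc1nc2cc(-c3nn(CCCCCCC(=O)NO)c4ncnc(N)c34)ccc2o1` alters only the chain that carries the hydroxycarbamoyl end. It is (hydroxycarbamoyl)methyl in place of hydroxycarbamoyl on a saturated chain carbon, five bonds along the chain from an aromatic nitrogen and reads in words as (hydroxycarbamoyl)methyl in place of hydroxycarbamoyl on a saturated chain carbon, five bonds along the chain from an aromatic nitrogen.

All three measured steps bear on this, as each of them varies the same chain. The widest change in chain length, a 1.2-fold higher number from compound 1 to compound 2 (0.07 log units; within the scatter) in this assay as well, is also within the scatter, and none of the three compounds goes against this flat picture. The chain of compound 4 is longer than that of compound 3 and shorter than that of compound 2, so it falls inside the span already measured.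

The expected size of the step is a 1.0-fold lower number from compound 3 to compound 4 (0.01 log units; within the scatter) and it is not expected to go beyond the scatter. For compound 4 the estimated value is 21000 nM with an expected range from 12000 nM to 36000 nM in this assay when measured.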

Compound 4, half-maximal inhibitory concentration: 5390 nM
For compound 4 the middle estimate is 3.9-fold (0.59 log units) above the measured one, outside the stated range (below it).
By their numbers in this assay, from the lowest: compound 4; then compounds 1, 3 and 2 (each within the scatter of the next).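

In this assay, among these compounds, the chain that carries the hydroxycarbamoyl end is no longer flat: (hydroxycarbamoyl)methyl in place of hydroxycarbamoyl, on a saturated chain carbon five bonds along the chain from an aromatic nitrogen, gives a 4.0-fold lower number from compound 3 to compound 4 (0.60 log units; beyond the scatter), the first step at this position to pass beyond the scatter. Compound 4 also stands apart from the shortest and longest chains shown, with a 3.6-fold lower number from compound 1 to compound 4 (0.56 log units; beyond the scatter) and a 4.3-fold lower number from compound 2 to compound 4 (0.63 log units; beyond the scatter), so among these four compounds the response to chain length is a single modest low point inside the measured span, not a steady trend. Nothing measured here accounts for why this one chain differs from the other three.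

The compounds shown leave open whether the low point is confined to the chain of compound 4 or also extends to a chain slightly longer than it, of a length lying short of that in compound 2. They also leave open whether a carboxylic acid or an amine at the end of that same chain, in place of the hydroxycarbamoyl group, would keep the lower number.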